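Thiophen-2-yl to 1H-imidazol-1-yl at an assay limit

The source may report more compounds than this note shows. Statements on the series, on what has been measured and on what is new or still open speak of the compounds shown alone.

Compound 1 `CCN(c1ccc(C#N)c(Cl)c1)c1cc(-c2ccc(F)nc2)ccc1C` and compound 2 `CCN(c1ccc(C#N)c(Cl)c1)c1cc(-c2cccs2)ccc1C` share one core and have both been tested in a functional assay on PC-3 cells (Homo sapiens) for antiproliferative activity, read by CCK-8 assay, with a stated time of 6 days; a lower number here means a stronger inhibitor, a higher number a weaker inhibitor. Compound 1 gives > 30000 nM, which is a limit of the assay and not a number. Compound 2 gives > 30000 nM, and this too is only a limit.

Compound 3 `CCN(c1ccc(C#N)c(Cl)c1)c1cc(-n2ccnc2)ccc1C` has not yet been measured. It carries 1H-imidazol-1-yl in place of thiophen-2-yl, on an aromatic carbon meta to a large group and para to a methyl group: 1H-imidazol-1-yl in place of thiophen-2-yl on an aromatic carbon.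

Among the compounds with values here, one measured step bears on this change, a different swap at the same carbon: a step that the two limits leave unreadable from compound 1 to compound 2. It therefore gives no size to carry over. What the measurements do show is the limit of > 30000 nM in this assay, at which 2 of the 2 values shown sit. On that basis, another swap of one aromatic ring for another is expected to leave the result near the limit. The estimated step is a number no higher from compound 2 to compound 3 (the limit leaves the size open), with no direction expected beyond the scatter. For compound 3 the expected value is 30000 nM, with an estimated range from 10000 nM to 60000 nM.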

Compound 3, half-maximal inhibitory concentration: > 30000 nM
Compound 3: no number, only a limit; the forecaster's own chance of this, stated with the estimate: 70%; the middle value lies on the limit itself.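

In this assay compound 3 gives > 30000 nM as a limit of the assay and not a number. Compound 1 and compound 2 also have only limits, so no step among these three compounds can be read. The compounds shown leave open how strong each one is and whether any aromatic ring at this carbon gives a readable number.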